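The source may hold more compounds than are shown below. What is called first, only, known or untested is meant among the compounds shown, and "the series" means these compounds.

Measured so far in a physicochemical assay for solubility, at pH 6.8; on this read-out lower numbers stand for lower solubility and higher numbers for higher solubility:

- compound 1 `Cn1cc(-c2ccc(N(C(=O)NCc3ccccc3)C3CCC(Nc4ccc(C#N)cn4)CC3)cc2)cn1`: 0.33 ug/mL
- compound 2 `N#Cc1ccc(NC2CCC(N(C(=O)NCc3ccccc3)c3ccccc3)CC2)nc1`: 4 ug/mL

Among the compounds with values here, compound 2, at 4 ug/mL, holds the higher of these two numbers, and compound 1 is its only neighbour. The next compound to consider is compound 3 `Cn1cccc(-c2ccc(N(C(=O)NCc3ccccc3)C3CCC(Nc4ccc(C#N)cn4)CC3)cc2)c1=O`, which is not yet measured. It differs from compound 2 by a single change: a group of 8 heavy atoms (6 carbon, 1 nitrogen, 1 oxygen; one six-membered aromatic ring with 1 hetero atom) in place of a hydrogen atom, on an aromatic carbon. The new group sits on an aromatic carbon of a six-membered aromatic ring of carbon only, para to a large group.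

Within the data shown here, one measured step bears on this: a 12-fold higher number from compound 1 to compound 2 (1.08 log units; beyond the scatter). That step is large and lies beyond the scatter, with hydrogen taking the place of 1-methyl-1H-pyrazol-4-yl on an aromatic carbon. The change to compound 3 runs the other way, since hydrogen leaves and a ring-bearing group enters. A single step is thin evidence, and the two groups are not the same. Going by compound 1 at 0.33 ug/mL, a large fall in this assay is still expected. The expected size is an 8.0-fold lower number from compound 2 to compound 3 (0.90 log units; beyond the scatter). Compound 3 is estimated at 0.5 ug/mL, with an expected range of 0.1 ug/mL to 2.5 ug/mL.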

Compound 3, solubility: 4.7 ug/mL
Beside the measured number, compound 3's estimate is 9.4-fold (0.97 log units) below it; the whole stated range lies below it.
By their numbers in this assay, from the lowest: compound 1; then compounds 2 and 3 (each within the scatter of the next).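

Placing the group of 8 heavy atoms, with its one six-membered aromatic ring with 1 hetero atom, on the aromatic carbon para to a large group gives a 1.2-fold higher number from compound 2 to compound 3 (0.07 log units; within the scatter) in this assay, so compound 2 and compound 3 cannot be told apart on this read-out. Within the data shown here, until now, the only ring-bearing group at this position, 1-methyl-1H-pyrazol-4-yl, had come with a much lower number than hydrogen, which could have suggested that any added ring there would do the same. Exchanging one ring-bearing group for the other at the same carbon gives a 14-fold higher number from compound 1 to compound 3 (1.15 log units; beyond the scatter) in this assay, showing that the outcome at this position depends on which group is attached and not simply on whether a ring-bearing group is present.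

With only these two ring-bearing groups shown, it remains open whether a plain phenyl ring, a morpholine ring or a carboxylic acid on this carbon would read like compound 3 or like compound 1. Nothing available here explains why the two ring-bearing groups part so widely.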